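Aryl-substituted fused pyranone series: antiproliferative read-out

The compounds below may be only part of what the source reports. "The series", "measured", "known", "first", "only" and "open" are said of these compounds alone.

Measured compounds in a functional assay on KBVIN cells (Homo sapiens) for antiproliferative activity, read by sulforhodamine B assay, with a stated time of 3 days; on this read-out higher numbers stand for an effect only at larger amounts of compound and lower numbers for an effect already at smaller amounts:
- compound 1, `CCCOc1ccc(-c2cc(=O)c3c(o2)C(CC)(CC)C(=O)C(CC)=C3O)cc1`: 29.2 uM
- compound 2, `CCC1=C(O)c2c(oc(-c3ccc(Br)cc3)cc2=O)C(CC)(CC)C1=O`: 15.7 uM
- compound 3, `CCC1=C(O)c2c(oc(-c3cc(C)c(OC)cc3C)cc2=O)C(CC)(CC)C1=O`: 7.58 uM

Compound 2 stands second highest of the three numbers. Its nearest neighbour is compound 1, whose number is higher, and the step of a 1.9-fold lower number from compound 1 to compound 2 (0.27 log units; within the scatter) lies within the scatter. Among the compounds with values here, compound 3 lies furthest from it, with a lower number beyond the scatter; no single-point step links compound 2 and compound 3, so their two values are merely set side by side.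

Compound 4, `CCC1=C(O)c2c(oc(-c3cccc(C)c3C)cc2=O)C(CC)(CC)C1=O`, is not yet measured. It differs from compound 2 by 2,3-dimethylphenyl in place of 4-bromophenyl on an aromatic carbon. Within the data shown here, the only measured step, from compound 1 to compound 2, exchanges one group on the same aromatic carbon and stays within the scatter; it does not bear closely on a change to a dimethyl-bearing phenyl. Compound 3, which also carries methyl groups on its phenyl, gives the lowest number shown, but no step to it is computed. For compound 4 the step of a 1.3-fold lower number from compound 2 to compound 4 (0.12 log units; within the scatter) is therefore expected to be small and not clearly beyond the scatter. The estimate for compound 4 in this assay is 12 uM, with a range from 5 uM to 35 uM.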

Compound 4, concentration for half-maximal effect: 0.85 uM
Compound 4: the middle estimate sits 14-fold (1.15 log units) above what was measured; measured number outside the range, below it.
By their numbers in this assay, from the lowest: compound 4; then compound 3; then compounds 2 and 1 (each within the scatter of the next).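

The aromatic carbon next to the ring oxygen is far from indifferent to what it carries. Exchanging 4-bromophenyl for 2,3-dimethylphenyl gives an 18-fold lower number from compound 2 to compound 4 (1.27 log units; beyond the scatter) in this assay and so moves well beyond the scatter, whereas the earlier exchange on the same carbon gave a 1.9-fold lower number from compound 1 to compound 2 (0.27 log units; within the scatter) and did not. No measurement on hand accounts for the size of this step.

The change removes bromine and brings in two methyl groups at once, so the compounds shown do not separate the loss of the one from the gain of the other, nor show whether a single methyl group on the phenyl would suffice. Also open, from the compounds shown here alone, is how the read-out responds to ethyl groups in place of the methyl groups, or to an amine or a carboxylic acid on this phenyl.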